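Phenyl in Place of Methoxyphenoxy: Cytotoxicity Expected Unchanged

This account rests on a few compounds, and the source may have more. Where it says the series, first, only, none or still open, it means among the compounds named here.

Compound 2 `COc1cccc(Oc2ccc3c(NCCCNCc4cccc(OC)c4O)ccnc3c2)c1` was tested in an ADME assay on HepG2 cells (Homo sapiens) for cytotoxicity, read by luminescence, CellTiter-Glo and ATP content, with a stated time of 72 h (a higher number here means that more compound is needed for the effect, a lower number that less compound is needed), and gives 5300 nM, the lower of the two numbers seen so far. Compound 1 `c1ccc(-c2ccc3c(NCCCNCc4ccco4)ccnc3c2)cc1` gives 5920 nM in this assay, within the scatter of compound 2. Compound 3 `COc1cccc(CNCCCNc2ccnc3cc(-c4ccccc4)ccc23)c1O` is not yet measured; relative to compound 2 it carries phenyl in place of 3-methoxyphenoxy on an aromatic carbon. Compound 1 already carries a phenyl at this place and lands within the scatter of compound 2, so no step beyond the scatter is expected here. Compound 3 is estimated to give 5600 nM in this assay, between 2500 nM and 12000 nM. The expected step of a 1.1-fold higher number from compound 2 to compound 3 (0.02 log units; within the scatter) should stay within the scatter.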

Compound 3, half-maximal effective concentration: 3210 nM
Compound 3: the middle estimate sits 1.7-fold (0.24 log units) above what was measured; measured number inside the range.
By their numbers in this assay, from the lowest: compounds 3, 2 and 1 (each within the scatter of the next).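

In this assay this aromatic carbon now has a direct comparison: phenyl in place of 3-methoxyphenoxy gives a 1.7-fold lower number from compound 2 to compound 3 (0.22 log units; within the scatter) even though the group shrinks from 9 heavy atoms to 6 and loses its 2 hydrogen-bond acceptors. At the other end of the molecule, 2-hydroxy-3-methoxyphenyl in place of furan-2-yl gives a 1.8-fold lower number from compound 1 to compound 3 (0.27 log units; within the scatter) and so this change also stays inside the scatter.

No supporting measurement bears on these results. As far as these compounds go, whether an amine or a carboxylic acid on this aromatic carbon would produce a step beyond the scatter remains open.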